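Swapping an aryl for a furan carbonyl on the piperazine

A few compounds are considered here, and "the series" means these few. Any claim that something is new, unique, unknown or untested is made for them only; others in the source may bear on it.

Measured so far:
- Compound 1, `COc1ccc(S(=O)(=O)NCCCN2CCN(c3ccc(C(F)(F)F)cc3)CC2)cc1`: 384 nM
- Compound 2, `COc1ccc(N2CCN(CCCNS(=O)(=O)c3ccc(OC)cc3)CC2)cc1`: 9310 nM
- Compound 3, `COc1ccc(S(=O)(=O)NCCCN2CCN(c3ccc([N+](=O)[O-])cc3)CC2)cc1`: > 10000 nM

All three compounds were tested in an assay on CHO cells for displacement of a labelled ligand from 5-hydroxytryptamine receptor 7 (Homo sapiens); on this read-out lower numbers stand for stronger inhibition and higher numbers for weaker inhibition. Compound 1 gives 384 nM. Compound 2 gives 9310 nM. For compound 3 the result is only a limit of the assay, > 10000 nM, so compound 3 sits at the weak end of the series, and the step of an at least 1.0-fold higher number from compound 2 to compound 3 (0.03 log units; that floor lies within the scatter) cannot be sized further than that floor.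

Compound 4, `COc1ccc(S(=O)(=O)NCCCN2CCN(C(=O)c3ccco3)CC2)cc1`, is not yet measured. It differs from compound 3 in one place: (furan-2-yl)carbonyl in place of 4-nitrophenyl on an amine nitrogen in a ring. This change no longer swaps one substituent on a phenyl ring for another, as the measured steps did; it removes the aryl group altogether and puts a carbonyl-linked five-membered ring on the piperazine nitrogen. The measured steps of a 24-fold higher number from compound 1 to compound 2 (1.38 log units; beyond the scatter) and an at least 26-fold higher number from compound 1 to compound 3 (1.41 log units; beyond the scatter) were both large and in the weakening direction, and they show only that this position is sensitive; none of them involves a carbonyl group.

Starting from a limit, no well-founded direction can be derived. Compound 4 is therefore expected to remain weak, with an estimated 10000 nM in this assay, in a range from 1500 nM to 40000 nM, which corresponds to an expected step of a number no higher from compound 3 to compound 4 (the limit leaves the size open).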

Compound 4, half-maximal inhibitory concentration: > 10000 nM
Compound 4: only a limit was reported; the forecaster's own chance of this, stated with the estimate: 55%; the middle value lies on the limit itself.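

In this assay compound 4 gives only a limit of the assay, > 10000 nM. The earlier steps changed only the substituent on a phenyl ring, whereas this change removes the aryl group altogether, and going from 4-(trifluoromethyl)phenyl to (furan-2-yl)carbonyl brings an at least 26-fold higher number from compound 1 to compound 4 (1.41 log units; beyond the scatter), so this carbonyl-linked five-membered ring does not match the best group shown at this position. Set against 4-methoxyphenyl, the change gives an at least 1.0-fold higher number from compound 2 to compound 4 (0.03 log units; that floor lies within the scatter), which is only a floor, and the step from compound 3 to compound 4 cannot be read, so the weak end of the series now rests on one limit: the limit of > 10000 nM in this assay, at which 2 of the 4 values shown sit.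

As far as these compounds go, how far compound 3 and compound 4 lie beyond that limit stays open, so the 4-nitrophenyl and (furan-2-yl)carbonyl groups cannot be ranked against each other. Also open, from the compounds shown here alone, is whether the loss comes with any carbonyl link on this nitrogen, or whether a benzoyl group, a plain phenyl or a 4-chlorophenyl would bring the number back towards compound 1 at 384 nM.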